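Anilide series: cytotoxicity check on the shared core

A few compounds are considered here, and "the series" means these few. Any claim that something is new, unique, unknown or untested is made for them only; others in the source may bear on it.

Compound 1 `COc1ccc2c(=O)c(/C=C/C(=O)Nc3cc(C)ccc3C)coc2c1` is tested in a functional assay on L02 cells (Homo sapiens) for inhibition, read by MTT assay, with a stated time of 48 h; a higher number here means a weaker inhibitor, a lower number a stronger inhibitor. In this assay compound 1 gives only a limit, > 200000 nM. Compound 2 `COc1ccc(NC(=O)/C=C/c2coc3cc(O)ccc3c2=O)cc1` also sits at a limit, > 200000 nM. Compound 3 `Cc1ccccc1NC(=O)/C=C/c1coc2cc(O)ccc2c1=O` likewise returns a limit, > 200000 nM. Within the data shown here, the one single-change step among them, a step that the two limits leave unreadable from compound 2 to compound 3, is therefore unreadable, since the limit of > 200000 nM in this assay, at which 3 of the 3 values shown sit, holds every value shown. Compound 4 `COc1ccc2c(=O)c(/C=C/C(=O)Nc3ccc(F)cc3)coc2c1` differs from compound 1 by 4-fluorophenyl in place of 2,5-dimethylphenyl on an amide-type nitrogen. Among the measured compounds shown here, no measured step bears on that change with a readable size, and all three values stand at the same limit. For compound 4 the expectation is therefore that this assay again reports a limit rather than a number. The step that the limit leaves unreadable from compound 1 to compound 4 is estimated as none beyond the scatter. Compound 4 is thus expected at 250000 nM, within 100000 nM to 1000000 nM.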

Compound 4, half-maximal inhibitory concentration: > 200000 nM
Compound 4: a limit, no number; the forecaster's own chance of this, stated with the estimate: 85%; the middle value lies beyond the limit too.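

Compound 1 and compound 4 both return only a limit, so no step can be read between them: the limit of > 200000 nM in this assay, at which 4 of the 4 values shown sit. The compounds shown leave open whether any change on the amide-type nitrogen alters the result at all.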